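Replacing fluoro by methoxy on the pendant phenyl ring

A few compounds are considered here, and "the series" means these few. Any claim that something is new, unique, unknown or untested is made for them only; others in the source may bear on it.

The series is built around one shared core, seen in compound 1 `CNC(=O)c1cc(Oc2ccc(NC(=O)c3cc4cccnc4n(-c4ccc(OC)cc4)c3=O)cc2)ccn1`, compound 2 `CCNC(=O)c1cc(Oc2ccc(NC(=O)c3cc4cccnc4n(-c4ccc(OC)cc4)c3=O)cc2)ccn1` and compound 3 `CCCNC(=O)c1cc(Oc2ccc(NC(=O)c3cc4cccnc4n(-c4ccc(F)cc4)c3=O)cc2)ccn1`, which differ in the amide chain on the pyridine and in the substituent on the phenyl ring attached to the core. In a functional assay on U-87MG ATCC cells for antiproliferative activity against U-87 MG (Homo sapiens), read by MTT assay, with a stated time of 72 h (a higher number here means a weaker inhibitor, a lower number a stronger inhibitor), compound 1 stands as "not determined" (no result reported), so no number is available for it. Compound 2 gives 7210 nM in this assay, while compound 3 gives 960 nM, the lowest of the two numbers; the gap between compound 2 and compound 3 lies beyond the scatter, but the two compounds differ in two places at once, so no single step can be read from it.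

Compound 4 `CCCNC(=O)c1cc(Oc2ccc(NC(=O)c3cc4cccnc4n(-c4ccc(OC)cc4)c3=O)cc2)ccn1` has not yet been measured in this assay. It differs from compound 3 in one place only: methoxy in place of fluoro on an aromatic carbon. Compound 2, which also carries the methoxy group, gives the weaker number, though its amide chain is shorter than that of compound 3. On that basis a modest rise in the number is expected from compound 3 to compound 4, a 2.6-fold higher number from compound 3 to compound 4 (0.42 log units; beyond the scatter), though a step within the scatter cannot be ruled out. Compound 4 is therefore estimated at 2500 nM in this assay, with a range from 900 nM to 7000 nM.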

Compound 4, half-maximal inhibitory concentration: 8210 nM
Beside the measured number, compound 4's estimate is 3.3-fold (0.52 log units) below it; measured number above the stated range.
By their numbers in this assay, from the lowest: compound 3; then compounds 2 and 4 (each within the scatter of the next).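

In this assay, the change from 4-fluorophenyl to 4-methoxyphenyl can now be read on its own, with the amide chain held constant, and this position on the pendant phenyl ring proves sensitive to the swap, with an 8.6-fold higher number from compound 3 to compound 4 (0.93 log units; beyond the scatter). The second comparison, with the methoxy group held constant, gives a 1.1-fold higher number from compound 2 to compound 4 (0.06 log units; within the scatter), so within this pair the extra methyl on the amide chain leaves the two compounds indistinguishable, and the gap that earlier mixed two differences now appears to follow the ring substituent rather than the chain, though the chain step has been read only with methoxy in place. Nothing measured here accounts for the effect of exchanging fluoro for methoxy at this position.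

The compounds shown leave open whether a chloro or a hydroxyl group at this position would give a number closer to that of the fluoro compound or to that of the methoxy compounds. They also leave open whether a butyl chain or a chain ending in an amine would change the picture, particularly with fluoro on the phenyl ring.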